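The source may report more compounds than this note shows. Statements on the series, on what has been measured and on what is new or still open speak of the compounds shown alone.

Measured compounds:
compound 1, `O=c1oc2cc(OCCCOc3ccc(Cl)cc3)ccc2s1`, 49.3%
compound 2, `Cc1ccc(OCCCOc2ccc3sc(=O)oc3c2)cc1`, 52.4%

Both compounds were tested in a functional assay on the whole organism (strain albino) for inhibition, with Mus musculus as the target, with stated times of 30 min and 5 min, at a dose of 60 mg/kg by the intraperitoneal route; a higher number here means more inhibition at the dose given (going by the name of the read-out), a lower number less inhibition. Compound 1 gives 49.3%, and compound 2 gives 52.4%. Compound 2 stands at the higher of the two numbers, but the gap, a number 3.1 percentage points higher from compound 1 to compound 2 (within the scatter), is within the scatter, so the two readings cannot be told apart.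

Compound 3, `O=c1oc2cc(OCCCOc3ccc([N+](=O)[O-])cc3)ccc2s1`, has not yet been measured. It differs from compound 2 in one place: nitro in place of methyl on an aromatic carbon. Within the data shown here, the only measured step that bears on this change is the one in which methyl replaces chloro on an aromatic carbon, and there the difference was a number 3.1 percentage points higher from compound 1 to compound 2 (within the scatter), a step within the scatter. Nothing measured shows what a nitro group does at this place, so the expectation rests on that single flat step and on the small size of the change. The expected step is therefore a number 2.4 percentage points lower from compound 2 to compound 3 (within the scatter), which means no change beyond the scatter. The estimate for compound 3 is 50%, with a range from 32% to 68%.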

Compound 3, a percentage reported as inhibition, in the whole organism at one dose (the size of the read-out at that dose, not a potency): 67.3%
Estimate against measurement, compound 3: 17.3 percentage points below; the measured number falls inside the stated range.
By their numbers in this assay, from the lowest: compounds 1 and 2 (each within the scatter of the next); then compound 3.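

The swap of methyl for chloro had left this assay flat, so this place, on an aromatic carbon of a six-membered aromatic ring of carbon only and para to a large group, could have seemed indifferent to what it carries. Nitro shows otherwise: the read-out gives a number 14.9 percentage points higher from compound 2 to compound 3 (beyond the scatter), and against the chloro compound it gives a number 18 percentage points higher from compound 1 to compound 3 (beyond the scatter), so the place does respond to the choice of group, and compound 3 stands above both other compounds at this one dose. The data give no measured property of these groups that would explain the rise, so the result stays an observation and not an explanation.

With only chloro, methyl and nitro at this place, the compounds shown leave open whether the rise belongs to nitro alone or would also appear with a nitrile, a trifluoromethyl group or an amine. They also leave open whether the same gain would hold with a longer chain between the two ends of the molecule, and how compound 3 would behave at other doses, since a single-dose reading is not a potency.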